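A few compounds are considered here, and "the series" means these few. Any claim that something is new, unique, unknown or untested is made for them only; others in the source may bear on it.

Of the compounds shown here, two with the same trimethoxyphenyl-bearing design have been measured so far. In a functional assay on A549 cells (Homo sapiens) for cytotoxicity (on this read-out lower numbers stand for stronger inhibition and higher numbers for weaker inhibition), compound 1 (`COc1cc(/C=C\c2ccc3ccccc3n2)cc(OC)c1OC`) gives 316 nM and compound 2 (`COc1cc(/C=C\c2cnc3ccccc3c2)cc(OC)c1OC`) gives 398 nM. These two values lie within the scatter of each other, so compound 2 stands level with compound 1 on the numbers available.

Compound 3 (`COc1cc(/C=C/c2cnc3ccccc3c2)cc(OC)c1OC`) is the next to be measured, and it is a very close relative of compound 2: the two compounds have the same atoms and bonds and differ only in configuration as drawn: 1 of 1 stereo elements differ; a double bond is drawn Z in compound 2 and E in compound 3. Put simply, the same atoms are joined in the same way, but a double bond is drawn Z in compound 2 and E in compound 3.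

For the measured compounds named here, no measured pair here shows what such a switch does, so the expectation rests on the structural change alone and remains uncertain. A move towards a higher number in this assay, clearly beyond the scatter, seems more likely than no change. The expected size is a 3.8-fold higher number from compound 2 to compound 3 (0.58 log units; beyond the scatter). For compound 3 the estimated value is 1500 nM, with an expected range of 100 nM to 20000 nM.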

Compound 3, half-maximal inhibitory concentration: > 3160 nM
Compound 3 ended at the assay's limit; the forecaster's own chance of this, stated with the estimate: 10%; at least 2.1-fold (0.32 log units) between middle value and limit.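

The earlier compounds shown here, 1 and 2, both have their double bond drawn Z, so they could not show what the configuration of that bond is worth; the switch from compound 2 to compound 3 isolates exactly that question. In this assay, turning the double bond from Z to E gives an at least 7.9-fold higher number from compound 2 to compound 3 (0.89 log units; beyond the scatter), a clear loss of cell-killing strength from a change that adds and removes no atoms. Compound 3 reads > 3160 nM, which is a limit of the assay and not a number, and the step can be tied to the double bond alone because of what the pair has in common: the fact that compounds 2 and 3 differ only in the configuration as drawn

The compounds shown leave open whether the same Z to E switch would cost as much in compound 1, whose double bond is joined to the ring system at a different point, so this single pair cannot yet be called a general rule. They also leave open whether the Z arrangement could be kept while the double bond is replaced by another link such as an amide, or while an amine is added to the shared core.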